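From Propyl to Cyclopentyl on an Amide Carbonyl

A few compounds are considered here, and "the series" means these few. Any claim that something is new, unique, unknown or untested is made for them only; others in the source may bear on it.

In an assay on CHO cells for displacement of a labelled ligand from adenosine receptor A1 (Homo sapiens), read by scintillation counting, with a stated time of 1 h, tested at 1 uM (a higher number here means more inhibition at the concentration tested (going by the name of the read-out), a lower number less inhibition), compound 1 `COc1ccccc1-c1cnc(N)nc1-c1ccccc1` gives 20%. Compound 2 `COc1ccc(-c2cnc(N)nc2-c2ccccc2)cc1Cl` reaches > 80%, which is a limit of this assay rather than a number. Compound 3 `CCCC(=O)Nc1ncc(-c2cccc(Cl)c2)c(-c2ccccc2)n1` likewise gives > 80%, again a limit and not a number. Compound 3 therefore stands at the limit of > 80% in this assay, at which 2 of the 3 values shown sit, so its true inhibition is known only as that limit, and no finer place among the values shown can be given to it.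

Compound 4 `O=C(Nc1ncc(-c2cccc(Cl)c2)c(-c2ccccc2)n1)C1CCCC1` differs from compound 3 in one place: cyclopentyl in place of propyl on a carbonyl carbon. Going by the values given here, no measured pair here shows what such a swap does, so there is no measured step to lean on. The change keeps the amide and its carbonyl, and no hydrogen-bond donors or acceptors leave or enter; one saturated carbon group simply replaces another.

The step is expected to be a step that the limit leaves unreadable from compound 3 to compound 4, nothing beyond the usual scatter. Compound 4 is thus expected to give 85%, with a range from 65% to 97%, and most likely it will again be reported only as a limit.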

Compound 4, a percentage reported as inhibition, at one concentration (the size of the read-out at that concentration, not a potency): 47%
Compound 4: middle estimate off by 38 percentage points, on the high side, and the stated range ends above it.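

In this assay, cyclopentyl in place of propyl on a carbonyl carbon gives a number at least 33 percentage points lower from compound 3 to compound 4 (beyond the scatter), so this position, on which the compounds shown had offered no measured step, does respond to a swap between two saturated carbon groups, even with no hydrogen-bond donor or acceptor entering or leaving. Compound 4 also gives this amide series a real number in this assay, one that later changes can move in either direction. The step can only be stated as a minimum because the value of compound 3 is a limit, not a number: the limit of > 80% in this assay, at which 2 of the 4 values shown sit.

Whether the ring or the added carbons account for the lower number stays open, as a pentyl chain would match the carbon count of cyclopentyl without a ring, while cyclopropyl would match propyl with one. Also open, going by these compounds, is how a carboxylic acid or an amine on the same chain would read.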